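This account rests on a few compounds, and the source may have more. Where it says the series, first, only, none or still open, it means among the compounds named here.

Measured compounds:
- compound 1, `COCCCn1cc(C(=O)Nc2ccc(-c3cn(C)c4ncnc(N)c34)cc2)c(=O)c(-c2ccc(F)cc2)c1`, gives > 10 nM in an assay on isolated protein for inhibition of tyrosine-protein kinase receptor UFO (Homo sapiens), read by ELISA; a lower number here means a stronger inhibitor, a higher number a weaker inhibitor
- compound 2, `Cc1cc(-c2cn(C)c3ncnc(N)c23)ccc1NC(=O)c1cn(CC2CCOCC2)cc(-c2ccc(F)cc2)c1=O`, gives 4 nM in this assay

The value for compound 1 is a limit of the assay and not a number; compound 1 therefore stands only at the weak end of what has been measured, and no numerical position can be assigned to it. Compound 2 carries a different chain on the ring nitrogen and an extra methyl on the anilide, so the two structures differ in more than one place and the gap between their values is not treated as a single step; what the two values show is that compound 2 sits inside the measurable range while compound 1 does not. Compound 3, `Cn1cc(C(=O)Nc2ccc(-c3cn(C)c4ncnc(N)c34)cc2)c(=O)c(-c2ccc(F)cc2)c1`, is the next member to be measured, and it differs from compound 1 by hydrogen in place of 2-methoxyethyl on a saturated chain carbon bound to an aromatic nitrogen. Going by the values given here, no measured step of this kind is available. Compound 3 is expected to move relative to compound 1 by about a step that the limit leaves unreadable from compound 1 to compound 3, which is a modest change and may well fall within the scatter. Compound 3 is estimated at 20 nM in this assay, with a range from 5 nM to 80 nM.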

Compound 3, half-maximal inhibitory concentration: 5 nM
The estimate for compound 3 lay 4.0-fold (0.60 log units) above the measured number; the measured number falls inside the stated range.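

In this assay compound 1 gives > 10 nM, which is a limit of the assay and not a number. Going from 3-methoxypropyl to methyl, that is, hydrogen in place of 2-methoxyethyl on a saturated chain carbon bound to an aromatic nitrogen, gives an at least 2.0-fold lower number from compound 1 to compound 3 (0.30 log units; that floor lies within the scatter), the first reading of any change at this position, and it places the methyl member inside the measurable range of this assay. The step is only a floor, so the direction can be taken no further than the printed reading and its true size stays unreadable, as it rests on a single limit: the limit of > 10 nM in this assay, at which 1 of the 3 values shown sits.

The compounds shown leave open how the value runs between the two ends at this position, for example with an ethyl or a plain propyl chain, and so whether chain length or the ether oxygen of the 3-methoxypropyl group matters. Also open, on these data alone, is how this position answers to a chain ending in an amine or a carboxylic acid.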